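This account rests on a few compounds, and the source may have more. Where it says the series, first, only, none or still open, it means among the compounds named here.

Measured compounds:
Compound 1, `O=c1ccoc2cc(OCc3cn(Cc4ccc(F)cc4)nn3)ccc12`. In a functional assay on SGC-7901 cells (Homo sapiens) for cytotoxicity, read by MTT assay, with a stated time of 48 h (a lower number here means a stronger inhibitor, a higher number a weaker inhibitor), compound 1 gives > 100000 nM, which is a limit of the assay.
Compound 2, `O=c1ccoc2cc(OCc3cn(Cc4cccc(Cl)c4)nn3)ccc12`. In this assay compound 2 gives > 100000 nM, again a limit.
Compound 3, `O=c1ccoc2cc(OCc3cn(Cc4ccc(Br)cc4)nn3)ccc12`. In this assay compound 3 gives > 100000 nM, also a limit.

Compound 3 therefore stands only at the limit, and it shares this position with the two others, since all three values sit at the limit of > 100000 nM in this assay, at which 3 of the 3 values shown sit. The changes among them, a step that the two limits leave unreadable from compound 1 to compound 2, a step that the two limits leave unreadable from compound 1 to compound 3 and a step that the two limits leave unreadable from compound 2 to compound 3, all leave the size of the step unreadable, because each end rests on a limit.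

Compound 4, `O=c1ccoc2cc(OCc3cn(Cc4ccccc4F)nn3)ccc12`, differs from compound 3 by 2-fluorophenyl in place of 4-bromophenyl on a saturated chain carbon bound to an aromatic nitrogen. The measured steps that touch this position, all unreadable, give no direction to expect beyond the scatter. Compound 4 is expected to stay at the limit as well, with an estimate of 150000 nM and a range from 50000 nM to 500000 nM. The expected step from compound 3 is a step that the limit leaves unreadable from compound 3 to compound 4, which is nominal only.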

Compound 4, half-maximal inhibitory concentration: > 100000 nM
Compound 4: only a limit was reported; the forecaster's own chance of this, stated with the estimate: 85%; the middle value does not contradict the limit.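

In this assay compound 4 gives > 100000 nM, which is a limit. Its steps from compound 1, compound 2 and compound 3 cannot be read, since all four compounds share one limit: the limit of > 100000 nM in this assay, at which 4 of the 4 values shown sit.

The compounds shown leave open how their true values compare and whether any change on the benzyl group affects cytotoxicity.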